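From pyridin-4-yl to cyclohexyl on compound 1

The source may report more compounds than this note shows. Statements on the series, on what has been measured and on what is new or still open speak of the compounds shown alone.

Compound 1 `O=C(OC1CCC(CN2CCN(c3cc(=O)c4cc(C(F)(F)F)cc([N+](=O)[O-])c4s3)CC2)CC1)c1ccncc1` gives 1%
Compound 2 `Nc1cc(C(F)(F)F)cc2c(=O)cc(N3CCN(CC4CCC(O)CC4)CC3)sc12` gives 72.9%

In an ADME assay on cells (Hepatocyte, Homo sapiens) for metabolic stability, with a stated time of 30 min (on this read-out higher numbers stand for a more stable compound and lower numbers for a less stable compound), compound 1 holds the lower of the two numbers, and compound 2 lies far above it, beyond the scatter. Compound 3 `O=C(OC1CCC(CN2CCN(c3cc(=O)c4cc(C(F)(F)F)cc([N+](=O)[O-])c4s3)CC2)CC1)C1CCCCC1` keeps the rest of compound 1 but carries cyclohexyl in place of pyridin-4-yl on a carbonyl carbon and has not yet been measured. Going by the values given here, compound 1 at 1% has little room to fall, and no measured pair shows this swap. A step of a number 2 percentage points higher from compound 1 to compound 3 (within the scatter) is expected, small and within the scatter. The estimate for compound 3 is 3% (expected range 0% to 15%).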

Compound 3, percent of the compound remaining: 2.8%
Compound 3: middle estimate off by 0.2 percentage points, on the high side, and the stated range covers the measured number.
By their numbers in this assay, from the lowest: compounds 1 and 3 (each within the scatter of the next); then compound 2.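

In this assay, putting cyclohexyl in place of pyridin-4-yl on a carbonyl carbon gives a number 1.8 percentage points higher from compound 1 to compound 3 (within the scatter). Here, an aromatic ring with one hetero atom and a non-aromatic ring of carbon only cannot be told apart, and both compounds sit near the bottom of the scale, where any further loss would be hard to see. Nothing measured here gives a reason for this result.

As far as these compounds go, whether a smaller group such as methyl, or an amine on the same carbonyl carbon, would read differently stays open. So does whether this swap would matter in a compound that starts from a higher number.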